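From methoxy to bromo on one aromatic ring

The source may report more compounds than this note shows. Statements on the series, on what has been measured and on what is new or still open speak of the compounds shown alone.

Measured in a functional assay on DU-145 cells (Homo sapiens) for cytotoxicity; a higher number here means a weaker inhibitor of growth, a lower number a stronger inhibitor of growth:
Compound 1 `COc1ccc(C2=C(c3ccc(SC)cc3)CC3CCCN3C2=O)cc1Br`: 900 nM
Compound 2 `CSc1ccc(C2=C(c3ccc(C)c(C)c3)C(=O)N3CCCC3C2)cc1`: 500 nM
Compound 3 `COc1ccc(C2=C(c3ccc(SC)cc3)CC3CCCN3C2=O)cc1`: 900 nM

Compound 3 stands level with compound 1, and compound 2 lies within the scatter of both. Compound 4 `CSc1ccc(C2=C(c3ccc(Br)cc3)C(=O)N3CCCC3C2)cc1` keeps the shared core but has bromo in place of methoxy on an aromatic carbon, turning 4-methoxyphenyl into 4-bromophenyl: bromo in place of methoxy on an aromatic carbon. Among the measured compounds shown here, no measured step makes this exact swap. Two bear on it: no change at the digits printed from compound 1 to compound 3 (within the scatter) comes with hydrogen in place of bromo on that ring, and a 1.8-fold higher number from compound 2 to compound 3 (0.26 log units; within the scatter) comes with a change of that whole group. Both stay within the scatter, so no step beyond the scatter is expected in this assay. The expected step is a 1.3-fold lower number from compound 3 to compound 4 (0.11 log units; within the scatter). Compound 4 is estimated at 700 nM, with an expected range of 250 nM to 2000 nM.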

Compound 4, concentration for 50% growth inhibition: 9000 nM
For compound 4 the middle estimate is 13-fold (1.11 log units) below the measured one, and the stated range ends below it.
By their numbers in this assay, from the lowest: compounds 2, 1 and 3 (each within the scatter of the next); then compound 4.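

In this assay, among the compounds shown here, earlier changes on this ring stayed within the scatter, but 4-bromophenyl gives a 10-fold higher number from compound 3 to compound 4 (1.00 log units; beyond the scatter), the first step here beyond it. Bromo on the ring is not enough to explain this, since the 3-bromo-4-methoxyphenyl group keeps the lower number, with a 10-fold higher number from compound 1 to compound 4 (1.00 log units; beyond the scatter). Losing methoxy is not enough either, since the 3,4-dimethylphenyl group also keeps it, with an 18-fold higher number from compound 2 to compound 4 (1.26 log units; beyond the scatter). Going by these compounds, whether an amine or an ethoxy group at this place would hold the lower number stays open. Nothing shown gives a reason for this jump.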